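Replacing the side chain of compound 2

The compounds below may be only part of what the source reports. "The series", "measured", "known", "first", "only" and "open" are said of these compounds alone.

Compound 1 `COc1ccc(/C=C\c2cc(OC)c(OC)c(OC)c2)cc1OCc1ccc(C=O)cc1` gives 900 nM
Compound 2 `COc1ccc(/C=C\c2cc(OC)c(OC)c(OC)c2)cc1OCc1ccc(CN2CCCCC2C(=O)NCCN)cc1` gives > 10000 nM

In a functional assay on MC-38 cells (Mus musculus) for antiproliferative activity, read by CCK-8 assay, with a stated time of 48 h (on this read-out lower numbers stand for stronger inhibition and higher numbers for weaker inhibition), compound 1 gives 900 nM as a real number. Compound 2 stands at > 10000 nM and this is a limit of the assay, not a number. Its place on the scale is known only as that limit.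

Compound 3 `COc1ccc(/C=C\c2cc(OC)c(OC)c(OC)c2)cc1OCc1ccc(CN[C@H](C(=O)O)[C@@H](C)O)cc1` has not yet been measured. It differs from compound 2 in one place, as counted in (1-carboxy-2-hydroxypropyl)amino in place of 2-((2-aminoethyl)carbamoyl)piperidin-1-yl on a saturated chain carbon bound to an aromatic carbon and put into words here: (1-carboxy-2-hydroxypropyl)amino in place of 2-((2-aminoethyl)carbamoyl)piperidin-1-yl on a saturated chain carbon bound to an aromatic carbon.

Going by the values given here, no two measured compounds differ in just one place, so no measured step guides the size of this change. The shared core does give a number in compound 1 at 900 nM and that leaves room for compound 3 to give one too. A modest step toward stronger inhibition in this assay is expected, estimated as an at least 2.5-fold lower number from compound 2 to compound 3 (0.39 log units; beyond the scatter) at this stage. For compound 3 the estimated value is 4000 nM with 1000 nM to 15000 nM as the expected range.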

Compound 3, half-maximal inhibitory concentration: > 10000 nM
Compound 3: a limit, no number (the forecaster's own chance of this, stated with the estimate: 35%); middle value at least 2.5-fold (0.39 log units) away from the limit.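

Compound 3 gives > 10000 nM in this assay, and this is a limit of the assay, not a number. The earlier compounds shown here showed only one large side chain ending without a number; now a second one, (1-carboxy-2-hydroxypropyl)amino, which has no ring, does the same at this saturated chain carbon bound to an aromatic carbon. Setting the whole ((1-carboxy-2-hydroxypropyl)amino)methyl group in place of formyl on an aromatic carbon gives an at least 11-fold higher number from compound 1 to compound 3 (1.04 log units; beyond the scatter), the first step in this set whose size can be read, and it is a large one in the direction of weaker inhibition.

The step between compound 2 and compound 3 cannot be read, because both stand at the same limit, so neither side chain can be ranked against the other: the limit of > 10000 nM in this assay, at which 2 of the 3 values shown sit.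
Still open, as far as these compounds go, is whether a much smaller group in place of formyl, such as aminomethyl or hydroxymethyl, would give a real number in this assay, and whether the carboxylic acid or the hydroxyl of the entering group is the part that goes with the large step from compound 1.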